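Allyl for Benzyl on the Thiourea of Compound 2

A few compounds are considered here, and "the series" means these few. Any claim that something is new, unique, unknown or untested is made for them only; others in the source may bear on it.

Measured compounds:
- compound 1, `CC(C)(C)/N=C(\S)NCCCCn1nc(-c2ccccc2)ccc1=O`: 33.6%
- compound 2, `O=c1ccc(-c2ccccc2)nn1CCCCNC(=S)NCc1ccccc1`: 5.4%
- compound 3, `C/N=C(/NC#N)NCCCCCn1nc(C)ccc1=O`: 14.9%

Of the compounds shown here, three have been measured in a functional assay on the whole organism with Rattus norvegicus as the target, at a dose of 100 mg/kg; on this read-out higher numbers stand for more inhibition at the one dose given (going by the name of the read-out) and lower numbers for less inhibition. Compound 2 holds the lowest number of the three; its value sits within the scatter of that of compound 3, while compound 1 lies beyond the scatter above it. The unmeasured compound 4, `C=CCNC(=S)NCCCCn1nc(-c2ccccc2)ccc1=O`, differs from compound 2 in one place: vinyl in place of phenyl on a saturated chain carbon bound to an amide-type nitrogen. Among the measured compounds shown here, no step between two measured compounds covers this change, so no direction can be read from the numbers at hand. Given the low number of compound 2, 5.4%, and the spread seen among the three, a modest rise is expected, with much of the range inside the scatter: a number 9.6 percentage points higher from compound 2 to compound 4 (within the scatter). Compound 4 is estimated at 15%, between 0% and 35%.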

Compound 4, a percentage reported as inhibition, in the whole organism at one dose (the size of the read-out at that dose, not a potency): 27.1%
Estimate against measurement, compound 4: 12.1 percentage points below; measured number inside the range.
By their numbers in this assay, from the lowest: compounds 2 and 3 (each within the scatter of the next); then compounds 4 and 1 (each within the scatter of the next).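

In this assay, among the compounds shown here, this position on the thiourea responds to the change: allyl for benzyl gives a number 21.7 percentage points higher from compound 2 to compound 4 (beyond the scatter), the first single-place step to show that this substituent matters. Set against the thiourea of compound 1, the ring-free allyl version gives a number 6.5 percentage points lower from compound 1 to compound 4 (within the scatter), so those two substituents are not told apart. Nothing measured here explains the rise. Still open, from the compounds shown here alone, is whether the double bond of allyl counts, which a propyl chain would test. A longer chain or a cyclohexylmethyl group at this place also remains untested in the compounds shown.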